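The source may report more compounds than this note shows. Statements on the series, on what has been measured and on what is new or still open speak of the compounds shown alone.

Three compounds share one core and differ at a single aromatic carbon. Compound 1 `Brc1cn2ccnc2c(-c2ccc3ncn(C4CCCCC4)c3c2)n1` gives 19.8% in a functional assay on UACC-62 cells (Homo sapiens) for inhibition, read by sulforhodamine B assay, with a stated time of 48 h, tested at 10 uM; a lower number here means less inhibition, a higher number more inhibition at the concentration tested (going by the name of the read-out). Compound 2 `c1ccc(-c2cn3ccnc3c(-c3ccc4ncn(C5CCCCC5)c4c3)n2)cc1` gives 65.7% in this assay, and compound 3 `COc1ccc(-c2cn3ccnc3c(-c3ccc4ncn(C5CCCCC5)c4c3)n2)cc1` gives 65.2%. Compound 3 thus stands second highest of the three numbers, its nearest neighbour being compound 2 within the scatter; the large steps were a number 45.9 percentage points higher from compound 1 to compound 2 (beyond the scatter) and a number 45.4 percentage points higher from compound 1 to compound 3 (beyond the scatter), whereas a number 0.5 percentage points lower from compound 2 to compound 3 (within the scatter). Compound 4 `O=Cc1ccc(-c2cn3ccnc3c(-c3ccc4ncn(C5CCCCC5)c4c3)n2)cc1` carries formyl in place of methoxy on an aromatic carbon. The step that bears on this is the one within the scatter, since the large steps concern the aryl group itself, which compound 4 keeps. Compound 4 is therefore expected to give about 60% in this assay, between 35% and 80%, the step estimated as a number 5.2 percentage points lower from compound 3 to compound 4 (within the scatter).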

Compound 4, a percentage reported as inhibition, at one concentration (the size of the read-out at that concentration, not a potency): 37.1%
Beside the measured number, compound 4's estimate is 22.9 percentage points above it; measured number inside the range.
By their numbers in this assay, from the lowest: compound 1; then compound 4; then compounds 3 and 2 (each within the scatter of the next).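

In this assay the substituent on this aromatic carbon turns out to matter: hydrogen and methoxy read alike, yet formyl in place of methoxy gives a clear loss (a number 28.1 percentage points lower from compound 3 to compound 4 (beyond the scatter)), and formyl in place of hydrogen gives one of similar size (a number 28.6 percentage points lower from compound 2 to compound 4 (beyond the scatter)). The 4-formylphenyl group still stands clear of bromo (a number 17.3 percentage points higher from compound 1 to compound 4 (beyond the scatter)), so part of the gain from the aryl group remains. Nothing available accounts for the loss with formyl. Going by these compounds, whether an amine, a hydroxymethyl group or a carboxylic acid at this carbon would read like formyl or like methoxy stays open.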